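Isobutyl for 3-fluorophenyl on the benzylic position

A few compounds are considered here, and "the series" means these few. Any claim that something is new, unique, unknown or untested is made for them only; others in the source may bear on it.

Compound 2 `Fc1cccc(Cn2ccc3nc(-c4ccccc4)nc-3c2)c1` was measured in an ADME assay on MDBK cells (Bos taurus) for cytotoxicity; on this read-out lower numbers stand for higher toxicity in this test and higher numbers for lower toxicity in this test. There compound 2 gives > 100000 nM, which is the limit of the assay rather than a number. Compound 1 `Fc1cccc(F)c1Cn1ccc2nc(-c3c(F)cccc3F)nc-2c1` in this assay likewise gives > 100000 nM, again a limit. Among the compounds with values here, compound 3 `c1ccc(-c2ccc(Cn3ccc4nc(-c5ccccc5)nc-4c3)cc2)cc1` is the one compound of the three with a measured number, giving 18000 nM in this assay. Compound 2 therefore stands where most of the shown values sit, as the limit of > 100000 nM in this assay, at which 2 of the 3 values shown sit, describes, and no step between two measured compounds that differ in a single place is available.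

Compound 4 `CC(C)CCn1ccc2nc(-c3ccccc3)nc-2c1` differs from compound 2 in one place: isobutyl in place of 3-fluorophenyl on a saturated chain carbon bound to an aromatic nitrogen. The ring bearing the fluorine is removed and a short branched chain takes its place on the saturated chain carbon bound to the aromatic nitrogen.

Since compound 2 in this assay shows > 100000 nM as a limit, the account expects that compound 4 will remain at or near that limit, and the expected step of a number no higher from compound 2 to compound 4 (the limit leaves the size open) is none beyond the scatter. For compound 4 the expected value in this assay is estimated at 100000 nM, with a range from 30000 nM to 300000 nM.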

Compound 4, half-maximal cytotoxic concentration: > 100000 nM
Compound 4: a limit, no number; the forecaster's own chance of this, stated with the estimate: 60%; the middle value lies on the limit itself.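

In this assay compound 4 gives > 100000 nM, which is a limit and not a number. Within the data shown here, compound 2 also stands at a limit, and no step between compound 2 and compound 4 can be read. The compounds shown leave open how isobutyl and 3-fluorophenyl compare in this read-out, as neither compound has a measured number.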